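Methylsulfonyl in Place of Butyl: Expected Cytotoxicity of Compound 4

The source may hold more compounds than are shown below. What is called first, only, known or untested is meant among the compounds shown, and "the series" means these compounds.

compound 1 `CC(C)COc1cc(-c2ccccc2)nc2ccccc12`: > 10 ug/mL
compound 2 `Oc1cc(-c2ccccc2)nc2cc(F)ccc12`: 3.45 ug/mL
compound 3 `CCCCOc1cc(-c2ccccc2)nc2ccccc12`: > 10 ug/mL

In a functional assay on HCT-8 cells (Homo sapiens) for cytotoxicity (on this read-out higher numbers stand for an effect only at larger amounts of compound and lower numbers for an effect already at smaller amounts), compound 1 gives > 10 ug/mL, which is a limit of the assay and not a number. Compound 3 likewise gives > 10 ug/mL, also a limit. Compound 2 gives 3.45 ug/mL. For the measured compounds named here, the single step between compounds differing in one place, a step that the two limits leave unreadable from compound 1 to compound 3, cannot be read because both ends sit at the limit of > 10 ug/mL in this assay, at which 2 of the 3 values shown sit. Compound 3 therefore stands at the limit, alongside one further value that is also a limit. Compound 4 `CS(=O)(=O)Oc1cc(-c2ccccc2)nc2ccccc12` differs from compound 3 by methylsulfonyl in place of butyl on an oxygen on an aromatic ring. Going by the values given here, no measured step bears on this change, so no size or direction beyond the scatter is expected in this assay. Compound 4 is expected to give 10 ug/mL, from 3 ug/mL to 30 ug/mL, an estimated step of a number no higher from compound 3 to compound 4 (the limit leaves the size open).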

Compound 4, half-maximal effective concentration: 5.6 ug/mL
Estimate against measurement, compound 4: 1.8-fold (0.25 log units) above; measured number inside the range.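

In this assay, for the compounds shown here, methylsulfonyl is the only group on this oxygen among compound 1, compound 3 and compound 4 that gives a number and not a limit. The change to it brings an at least 1.7-fold lower number from compound 3 to compound 4 (0.25 log units; that floor lies within the scatter), and the change from isobutyl brings an at least 1.7-fold lower number from compound 1 to compound 4 (0.25 log units; that floor lies within the scatter). These are floors only, and the full size of either step stays open because the butyl and isobutyl compounds sit at a limit: the limit of > 10 ug/mL in this assay, at which 2 of the 4 values shown sit.

The compounds shown leave open whether another group on this oxygen, such as acetyl or a longer sulfonyl chain, would also give a number. They also leave open what an amine in place of this oxygen would give.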